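The source may report more compounds than this note shows. Statements on the series, on what has been measured and on what is new or still open speak of the compounds shown alone.

Compound 2 `COc1ccccc1-c1nnc(-c2ccc(C(=O)N/N=C/c3ccccc3[N+](=O)[O-])cc2)o1` belongs to a small set of two measured compounds built on a shared core. In an ADME assay on THP-1 cells (Homo sapiens) for cytotoxicity (on this read-out lower numbers stand for stronger inhibition and higher numbers for weaker inhibition), compound 2 gives 161000 nM, the lowest of the two numbers; its nearest neighbour, compound 1 `COc1ccccc1-c1nnc(-c2ccc(C(=O)N/N=C/c3cccc(O)c3)cc2)o1`, gives 398000 nM. Within the data shown here, the one measured step, a 2.5-fold lower number from compound 1 to compound 2 (0.39 log units; beyond the scatter), is the only one that speaks to the present change.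

Compound 3 `COc1ccccc1-c1nnc(-c2ccc(C(=O)N/N=C/c3ccc(O)c(O)c3)cc2)o1` has not yet been measured in this assay. It differs from compound 2 by 3,4-dihydroxyphenyl in place of 2-nitrophenyl on a carbon with a double bond to nitrogen. This change runs in the opposite sense to the step from compound 1 to compound 2: a hydroxyphenyl group returns, now carrying two hydroxyls, in place of the 2-nitrophenyl. Because a 2.5-fold lower number from compound 1 to compound 2 (0.39 log units; beyond the scatter) was modest but beyond the scatter, a step of similar size in the reverse direction is expected here, that is a higher number for compound 3 than for compound 2. The estimated step is a 2.0-fold higher number from compound 2 to compound 3 (0.30 log units; within the scatter). Compound 3 is therefore expected to give about 320000 nM in this assay, with a range from 150000 nM to 650000 nM.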

Compound 3, half-maximal inhibitory concentration: 100000 nM
Estimate against measurement, compound 3: 3.2-fold (0.51 log units) above; measured number below the stated range.
By their numbers in this assay, from the lowest: compounds 3 and 2 (each within the scatter of the next); then compound 1.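

In this assay, 3,4-dihydroxyphenyl in place of 2-nitrophenyl on the carbon with a double bond to nitrogen gives a 1.6-fold lower number from compound 2 to compound 3 (0.21 log units; within the scatter), so compound 3 and compound 2 cannot be told apart. Among these compounds, this shows that a hydroxylated ring at this place can read level with 2-nitrophenyl, which the single earlier step, with its one hydroxyphenyl ring, did not show. Hydroxy in place of hydrogen on an aromatic carbon gives a 4.0-fold lower number from compound 1 to compound 3 (0.60 log units; beyond the scatter), so the ring's substitution pattern matters here, and the hydroxyphenyl ring of compound 1 does not set the level for hydroxylated rings at this place; nothing available explains either step.

The compounds shown leave open whether the lower number of compound 3 depends on the added hydroxy itself or on where it sits on the ring, as a 4-hydroxyphenyl ring could help to separate. They also leave open whether a methoxy group or an amine on the same ring would read like the hydroxy or like the nitro group.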